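The source may report more compounds than this note shows. Statements on the series, on what has been measured and on what is new or still open speak of the compounds shown alone.

Measured in a functional assay on SH-SY5Y cells (Homo sapiens) for cytotoxicity, read by MTT assay, with a stated time of 72 h; a higher number here means a weaker inhibitor, a lower number a stronger inhibitor:
- Compound 1 `O=C1c2c[n+]([O-])c3ccccc3c2C(=O)c2c1c1ccccc1n2Cc1cn(C[C@H](O)CO)nn1`: > 1000 nM (a limit)
- Compound 2 `CN1CCN(CCCCn2c3c(c4ccccc42)C(=O)c2c[n+]([O-])c4ccccc4c2C3=O)CC1`: 100 nM
- Compound 3 `CCCN1CCN(CCCCn2c3c(c4ccccc42)C(=O)c2c[n+]([O-])c4ccccc4c2C3=O)CC1`: 3970 nM

Compound 3 holds the higher of the two exact numbers in this assay. The change to compound 4 `O=C1c2c[n+]([O-])c3ccccc3c2C(=O)c2c1c1ccccc1n2CCN1CCCCC1` is piperidin-1-yl in place of 2-(4-propylpiperazin-1-yl)ethyl on a saturated chain carbon, two bonds along the chain from an aromatic nitrogen, with piperidin-1-yl in place of 2-(4-propylpiperazin-1-yl)ethyl on a saturated chain carbon, two bonds along the chain from an aromatic nitrogen. Within the data shown here, two measured steps bear on this: a 40-fold higher number from compound 2 to compound 3 (1.60 log units; beyond the scatter), a large one, and an at least 10-fold lower number from compound 1 to compound 2 (1.00 log units; beyond the scatter), at least modest. Both show that changes in this side chain can move the number well beyond the scatter. A step of a 5.0-fold lower number from compound 3 to compound 4 (0.70 log units; beyond the scatter) is therefore expected, back towards lower numbers. For compound 4 the estimated value is 800 nM, with an expected range of 150 nM to 4000 nM.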

Compound 4, half-maximal inhibitory concentration: 1860 nM
Compound 4: middle estimate off by 2.3-fold (0.37 log units), on the low side, within the range that was stated.
By their numbers in this assay, from the lowest: compound 2; then compound 4; then compound 3.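

Piperidin-1-yl in place of 2-(4-propylpiperazin-1-yl)ethyl gives only a modest change, a 2.1-fold lower number from compound 3 to compound 4 (0.33 log units; beyond the scatter), while the same replacement of 2-(4-methylpiperazin-1-yl)ethyl gives a large one, a 19-fold higher number from compound 2 to compound 4 (1.27 log units; beyond the scatter). The size of this change therefore depends on the group it replaces, and neither compound 3 nor compound 4 reaches the number of compound 2. Compound 1 carries a limit, so its step to compound 4 cannot be read: the limit of > 1000 nM in this assay, at which 1 of the 4 values shown sits.

The compounds shown leave open how piperidin-1-yl would read on a longer chain, since this change alters the ring and the chain together. They also leave open how a 4-ethylpiperazin-1-yl group would compare with the methyl and propyl versions.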